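The source may hold more compounds than are shown below. What is called first, only, known or untested is meant among the compounds shown, and "the series" means these compounds.

Compound 1 `CCCCN(c1nc2c(C(=O)O)cccc2o1)[C@H](C)c1ccc(-c2ccccc2-c2nnn[nH]2)cc1` is the weaker of the two measured compounds in an ADME assay on the whole organism (Macaca fascicularis) for pharmacokinetics, read by LC-MS, using cassette dosing (a lower number here means that a smaller share of the oral dose reaches the circulation, a higher number that a larger share of the oral dose reaches the circulation), where compound 1 gives 8.2%. Compound 2 `Cc1ccc(-c2nc(=O)o[nH]2)c(-c2ccc([C@@H](C)N(CC3CC3)c3nc4c(C(=O)O)cccc4o3)cc2)c1` reaches 58% in this assay, a gap well beyond the usual scatter. Compound 3 `CCCCN(c1nc2c(C(=O)N(C)C)cccc2o1)[C@H](C)c1ccc(-c2ccccc2-c2nnn[nH]2)cc1` differs from compound 1 by a single change, (dimethylamino in place of hydroxy on a carbonyl carbon), that is, carboxy becomes dimethylcarbamoyl. Going by the values given here, no measured pair shows this exact change, so the expected step from compound 1 to compound 3 in this assay, a number 16.8 percentage points higher from compound 1 to compound 3 (beyond the scatter), is an upward guess of moderate size. Compound 3 is therefore estimated at 25%, within a range of 8% to 55%.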

Compound 3, oral bioavailability: 6.7%
Beside the measured number, compound 3's estimate is 18.3 percentage points above it, outside the stated range (below it).
By their numbers in this assay, from the lowest: compounds 3 and 1 (each within the scatter of the next); then compound 2.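

Exchanging hydroxy for dimethylamino on the carbonyl carbon gives a number 1.5 percentage points lower from compound 1 to compound 3 (within the scatter) in this assay, so carboxy and dimethylcarbamoyl cannot be told apart here. At this position, on the core of compound 1, removing the carboxy group's hydrogen-bond donor therefore brings no measurable gain in oral exposure. Nothing available explains this result.

As far as these compounds go, whether a plain amino group or a methoxy group on the same carbonyl carbon would read the same remains open. So does whether this change would have a similar outcome on the core of compound 2.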